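The source may hold more compounds than are shown below. What is called first, only, known or untested is meant among the compounds shown, and "the series" means these compounds.

Of the compounds shown here, three have been measured in a functional assay on IGROV-1 cells (Homo sapiens) for cytotoxicity, read by sulforhodamine B assay, with a stated time of 48 h, tested at 1 uM (on this read-out higher numbers stand for a weaker effect at the one concentration tested and lower numbers for a stronger effect), so far. Compound 1, with the structure `COc1ccc(-c2cc(/C=C/C(=O)c3ccc(OC)c(OC)c3)[nH]n2)cc1`, gives 77%. Compound 2, with the structure `COc1cc(-c2cc(/C=C/C(=O)c3ccc(Cl)c(Cl)c3)[nH]n2)cc(OC)c1OC`, gives 99%, and compound 3, with the structure `COc1ccc(-c2cc(/C=C/C(=O)c3ccc(N)cc3)[nH]n2)cc1`, gives 89%. On these numbers compound 2 has the highest value of the three; its number lies within the usual scatter of the value for compound 3, while the distance to compound 1 is beyond that scatter. Compound 4, with the structure `COc1ccc(C(=O)/C=C/c2cc(-c3cc(OC)c(OC)c(OC)c3)n[nH]2)cc1OC`, has not yet been measured in this assay. It differs from compound 2 in one place: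

3,4-dimethoxyphenyl in place of 3,4-dichlorophenyl on a carbonyl carbon

For the measured compounds named here, no measured pair here shows what this kind of exchange does, so the size of the step is uncertain. Compound 1, which also carries a 3,4-dimethoxyphenyl on its carbonyl carbon, gives 77%, the lowest number in the set, which gives some reason to expect a modest move downward. In this assay compound 4 is therefore estimated at 86%, with a range from 68% to 100%. This estimate corresponds to an expected step of a number 13 percentage points lower from compound 2 to compound 4 (beyond the scatter), a change that could still fall within the scatter.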

Compound 4, a percentage reported as activity, at one concentration (the size of the read-out at that concentration, not a potency): 96%
The estimate for compound 4 lay 10 percentage points below the measured number, and the stated range covers the measured number.
By their numbers in this assay, from the lowest: compound 1; then compounds 3, 4 and 2 (each within the scatter of the next).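

In this assay, for the compounds shown here, placing 3,4-dimethoxyphenyl instead of 3,4-dichlorophenyl on the carbonyl carbon gives a number 3 percentage points lower from compound 2 to compound 4 (within the scatter), the first direct reading of this exchange with the rest of the molecule held constant. On this core, then, the exchange has no effect that can be told apart from ordinary assay scatter, even though one group carries chlorine atoms and the other carries oxygen-containing methoxy groups. Nothing measured here bears on the reason for this result.

This single pair leaves open whether the same exchange would read alike on a different core, such as that of compound 1. It also leaves open whether a carboxylic acid or a nitrile on this phenyl ring would shift the number beyond the scatter.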